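Swapping Cyclohexyl for Fluorophenyl on the Ether Chain

The source may report more compounds than this note shows. Statements on the series, on what has been measured and on what is new or still open speak of the compounds shown alone.

Three compounds sharing one core were measured in a functional assay on HEK293 cells for negative allosteric modulation of metabotropic glutamate receptor 5 (Homo sapiens), read by FLIPR and calcium flux; a lower number here means a stronger inhibitor, a higher number a weaker inhibitor. Compound 1 `Cc1cccc(NC(=O)c2nn(C)c(-c3ccc(F)cc3)c2C)n1` gives 1.1 nM in this assay. Compound 2 `Cc1cccc(NC(=O)c2nn(C)c(OC3CCCCC3)c2C)n1` gives 92 nM, and compound 3 `Cc1cccc(NC(=O)c2nn(C)c(OCC3CCCCC3)c2C)n1` gives 1300 nM. Compound 3 thus holds the highest number of the three: the change a 1200-fold higher number from compound 1 to compound 3 (3.07 log units; beyond the scatter) was large, and even the shorter step a 14-fold higher number from compound 2 to compound 3 (1.15 log units; beyond the scatter) was clearly beyond the scatter.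

Compound 4 `Cc1cccc(NC(=O)c2nn(C)c(OCc3ccc(F)cc3)c2C)n1` differs from compound 3 by 4-fluorophenyl in place of cyclohexyl on a saturated chain carbon bound to an oxygen on an aromatic ring. For the measured compounds named here, no measured step places an aromatic ring in exactly this spot; the nearest guide is that compound 1, carrying the same 4-fluorophenyl directly on the aromatic carbon, gives a far lower number, as a 1200-fold higher number from compound 1 to compound 3 (3.07 log units; beyond the scatter) shows, while a 14-fold higher number from compound 2 to compound 3 (1.15 log units; beyond the scatter) shows how costly the extra chain carbon was. Since the chain carbon stays in place in compound 4, only part of that loss is expected to be recovered. Compound 4 is therefore expected to improve moderately on compound 3 in this assay, a step of a 2.9-fold lower number from compound 3 to compound 4 (0.46 log units; beyond the scatter). The estimate for compound 4 is 450 nM, with a plausible range from 120 nM to 1800 nM.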

Compound 4, half-maximal inhibitory concentration: 911 nM
Estimate against measurement, compound 4: 2.0-fold (0.31 log units) below; the measured number falls inside the stated range.
By their numbers in this assay, from the lowest: compound 1; then compound 2; then compounds 4 and 3 (each within the scatter of the next).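

At this position, on a saturated chain carbon bound to an oxygen on an aromatic ring, the two six-membered rings cannot be told apart in this assay: 4-fluorophenyl in place of cyclohexyl leaves the number within the scatter (a 1.4-fold lower number from compound 3 to compound 4 (0.15 log units; within the scatter)). The comparison with compound 2 also holds for the aromatic ring, since 4-fluorobenzyl in place of cyclohexyl on the oxygen costs a step beyond the scatter (a 9.9-fold higher number from compound 2 to compound 4 (1.00 log units; beyond the scatter)), as cyclohexylmethyl did (a 14-fold higher number from compound 2 to compound 3 (1.15 log units; beyond the scatter)). The 4-fluorophenyl group therefore does not bring with it the low number of compound 1 (1.1 nM) once it stands on this chain carbon, so its effect depends on where it is attached in these compounds.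

The compounds shown leave open whether an amine or a carboxylic acid on this chain carbon, a longer chain between the oxygen and the ring, or an unsubstituted phenyl would separate from compound 3 and compound 4 in this assay. The data shown offer no measurement that explains why the 4-fluorophenyl group behaves so differently in compound 1 and compound 4.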